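Two potent analogues and a change at the nitro-bearing ring

This account rests on a few compounds, and the source may have more. Where it says the series, first, only, none or still open, it means among the compounds named here.

Measured compounds:
compound 1: `CC1(C)CCC(CN2CCN(c3ccc(C(=O)NS(=O)(=O)c4ccc(NCC5CCOCC5)c([N+](=O)[O-])c4)c(Oc4cnc5[nH]ccc5c4)c3)CC2)=C(c2ccccc2C(F)(F)F)C1` — 1.7 nM
compound 2: `CN1CCC(CNc2ccc(S(=O)(=O)NC(=O)c3ccc(N4CCN(CC5=C(c6ccc(C(F)(F)F)cc6)CC(C)(C)CC5)CC4)cc3Oc3cnc4[nH]ccc4c3)cc2[N+](=O)[O-])C1` — 2.4 nM

In an assay on isolated protein for displacement of a labelled ligand from Apoptosis regulator Bcl-2 (Homo sapiens), with a stated time of 15 min (a lower number here means a stronger inhibitor, a higher number a weaker inhibitor), compound 2 gives 2.4 nM, and compound 1 gives 1.7 nM in this assay; the two numbers lie within the usual scatter of each other, so neither can be set apart from the other.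

Compound 3, `CC1(C)CCC(CN2CCN(c3ccc(C(=O)NS(=O)(=O)c4ccc(OCC5CCSCC5)c([N+](=O)[O-])c4)c(Oc4cnc5[nH]ccc5c4)c3)CC2)=C(c2ccc(C(F)(F)F)cc2)C1`, has not been measured. Compared with compound 2 it carries a group of 8 heavy atoms (6 carbon, 1 oxygen, 1 sulfur; one six-membered non-aromatic ring with 1 hetero atom) in place of a group of 8 heavy atoms (6 carbon, 2 nitrogen; one five-membered non-aromatic ring with 1 hetero atom), on an aromatic carbon. Going by the values given here, since no step between two measured compounds involves this part of the molecule, the data give no direct guide to its effect. With compound 2 at 2.4 nM in this assay, and with both measured compounds close together, the expectation is that the step from compound 2 to compound 3 in this assay stays close to or barely beyond the scatter, a 1.5-fold higher number from compound 2 to compound 3 (0.16 log units; within the scatter), leaning toward a slightly higher number. The estimate for compound 3 is therefore 3.5 nM, with a range from 1.2 nM to 12 nM.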

Compound 3, half-maximal inhibitory concentration: 1.65 nM
Estimate against measurement, compound 3: 2.1-fold (0.33 log units) above; the range from low to high includes it.
By their numbers in this assay, from the lowest: compounds 3, 1 and 2 (each within the scatter of the next).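

In this assay, the group on the aromatic carbon ortho to the nitro group shows that ((1-methylpyrrolidin-3-yl)methyl)amino can give way to a group with 6 carbon, 1 oxygen and 1 sulfur among its 8 heavy atoms, with a 1.5-fold lower number from compound 2 to compound 3 (0.16 log units; within the scatter) as the result and no difference that can be read. The exchange replaces a five-membered non-aromatic ring with a six-membered one and goes from 1 hydrogen-bond donor to 0 hydrogen-bond donors, so neither feature of the leaving group is required here for a value in this range. This single step cannot separate ring size, hetero atom and donor count, and the compounds shown leave open whether a carboxylic acid or a longer chain at this place would fare alike. No measurement at hand speaks to what lies behind this agreement.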